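Side-chain variation in the shared core series

The source may hold more compounds than are shown below. What is called first, only, known or untested is meant among the compounds shown, and "the series" means these compounds.

compound 1 `c1ccc2c(c1)CCC2CCCN1CCN(c2cccc3c2OCCO3)CC1`: 0.23 mg/kg
compound 2 `c1ccc2c(c1)CC2CN1CCN(c2cccc3c2OCCCO3)CC1`: < 2.5 mg/kg

In an assay for activation of Adrenergic receptor alpha-1 (Rattus norvegicus) (on this read-out higher numbers stand for an effect only at larger amounts of compound and lower numbers for an effect already at smaller amounts), compound 1 gives 0.23 mg/kg. For compound 2 this assay reports only a limit, < 2.5 mg/kg, which is the limit of < 2.5 mg/kg in this assay, at which 1 of the 2 values shown sits; compound 2 therefore stands at a limit and not at a number. Compound 3 `c1ccc2c(c1)CC2CCN1CCN(c2cccc3c2OCCCO3)CC1` differs from compound 2 by a group of 9 heavy atoms (9 carbon; one four-membered non-aromatic ring of carbon only, one six-membered aromatic ring of carbon only) in place of a group of 8 heavy atoms (8 carbon; one four-membered non-aromatic ring of carbon only, one six-membered aromatic ring of carbon only), on a saturated chain carbon bound to an amine nitrogen in a ring. For the measured compounds named here, no measured step covers this change, so no size of step is established for it; a shift within the usual scatter, in either direction, is as plausible as any. Compound 3 is expected at 0.6 mg/kg, with a range from 0.1 mg/kg to 2.5 mg/kg. This estimate for compound 3 amounts to an expected step that the limit leaves unreadable from compound 2 to compound 3.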

Compound 3, dose for half-maximal effect: 6.96 mg/kg
Compound 3: the middle estimate sits 12-fold (1.06 log units) below what was measured; the whole stated range lies below it.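

For the compounds shown here, on the saturated chain carbon bound to an amine nitrogen in a ring, the group of 9 heavy atoms in place of the group of 8 heavy atoms gives the first readable step for this change in this assay: an at least 2.7-fold higher number from compound 2 to compound 3 (0.44 log units; beyond the scatter). The change therefore moves the read-out beyond the scatter, towards effect only at larger amounts of compound. Compound 2 stands at a limit, so the true step may be larger: the limit of < 2.5 mg/kg in this assay, at which 1 of the 3 values shown sits.

Open, going by these compounds, is whether a longer chain at this place would move the read-out further in the same direction. Going by these compounds alone, compound 1 differs from compound 2 and compound 3 in more than one place, so it gives no step on this change.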